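Fluoro for chloro on a salicylanilide core, and solubility

The source may hold more compounds than are shown below. What is called first, only, known or untested is meant among the compounds shown, and "the series" means these compounds.

The series comprises three measured salicylanilides and one not yet measured. Compound 1 `O=C(Nc1ccc(F)cc1Cl)c1cc(Cl)ccc1O` and compound 2 `O=C(Nc1ccc(Cl)cc1Cl)c1cc(Cl)ccc1O` share a core and differ in a single place; compound 3 `O=C(Nc1ccc(C(F)(F)F)c(Cl)c1)c1cc(Br)ccc1O` carries a bromo and a trifluoromethyl group, and the difference between its core and the core of compound 2 is not broken down here. In a physicochemical assay for solubility (a higher number here means a more soluble compound, a lower number a less soluble compound), compound 1 gives 1.2 ug/mL. For compound 2 in this assay only a limit is reported, < 1 ug/mL. For compound 3 in this assay likewise only a limit is reported, < 1 ug/mL; compound 3 thus sits at the limit of < 1 ug/mL in this assay, at which 2 of the 3 values shown sit.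

Among the compounds with values here, the one counted step, (fluoro in place of chloro on an aromatic carbon), gave an at least 1.2-fold higher number from compound 2 to compound 1 (0.07 log units; that floor lies within the scatter).

Compound 4 `O=C(Nc1ccc(C(F)(F)F)c(F)c1)c1cc(Br)ccc1O` is made from compound 3 by fluoro in place of chloro on an aromatic carbon. This is the same kind of change as that from compound 2 to compound 1, but the place differs: here the fluoro enters ortho to a trifluoromethyl group and meta to a large group, whereas before it entered meta to a chloro group and para to a large group. Since compound 3 is reported only as a limit and the earlier step is itself only a floor, a small upward step is expected, a number no lower from compound 3 to compound 4 (the limit leaves the size open), resting on an at least 1.2-fold higher number from compound 2 to compound 1 (0.07 log units; that floor lies within the scatter). Compound 4 is therefore estimated to give 1 ug/mL in this assay, with a range expected from 0.3 ug/mL to 3 ug/mL, and a fair chance that only a limit is again reported.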

Compound 4, solubility: < 1 ug/mL
Compound 4: no number, only a limit (the forecaster's own chance of this, stated with the estimate: 50%); the middle value lies on the limit itself.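

In this assay compound 4 gives < 1 ug/mL, which is a limit and not a number. Compound 3 also has only a limit, so no step can be read from compound 3 to compound 4: the limit of < 1 ug/mL in this assay, at which 3 of the 4 values shown sit.

The compounds shown leave open how large the solubility change is, if there is any, when fluoro replaces chloro on an aromatic carbon ortho to a trifluoromethyl group.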